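A few compounds are considered here, and "the series" means these few. Any claim that something is new, unique, unknown or untested is made for them only; others in the source may bear on it.

Measured in an ADME assay on liver for metabolic stability, with Liver microsome (Homo sapiens) as the target, read by LC-MS, using microsomes; on this read-out higher numbers stand for fast clearance and lower numbers for slow clearance:
- Compound 1 `CC(C)(C)[C@@H](O)C(=O)N1CSC(C)(C)[C@H]1C(=O)NCc1cc(Cl)ccc1-n1cnnn1`: 360 mL.min-1.g-1
- Compound 2 `O=C(NCc1cc(Cl)ccc1-n1cnnn1)[C@@H]1CCNN1C(=O)[C@H](O)c1ccccc1`: < 16 mL.min-1.g-1, a limit
- Compound 3 `O=C(NCc1cc(Cl)ccc1-n1cnnn1)[C@@H]1CCON1C(=O)[C@H](O)c1ccccc1`: < 12 mL.min-1.g-1, a limit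

Compound 2 stands only at a limit, < 16 mL.min-1.g-1, and not at a number. Compound 4 `CC(C)(C)[C@@H](O)C(=O)N1NCC[C@H]1C(=O)NCc1cc(Cl)ccc1-n1cnnn1` keeps the core of compound 2 and carries tert-butyl in place of phenyl on a saturated chain carbon bound to a carbonyl carbon and an oxygen on a saturated carbon. For the measured compounds named here, no measured pair shows this change alone. Going by the values given here, the only guide is compound 1, which carries the same tert-butyl on a different core and gives 360 mL.min-1.g-1. A moderate rise in this assay is therefore expected, far short of that value. The expected change is an at least 1.8-fold higher number from compound 2 to compound 4 (0.27 log units; that floor lies within the scatter). Compound 4 is estimated at 30 mL.min-1.g-1, with an expected range of 12 mL.min-1.g-1 to 120 mL.min-1.g-1.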

Compound 4, intrinsic clearance in microsomes: 15 mL.min-1.g-1
The estimate for compound 4 lay 2.0-fold (0.30 log units) above the measured number, and the stated range covers the measured number.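

For the compounds shown here, compound 2 is known only as a limit, so no step from compound 2 to compound 4 can be read. The compounds shown leave open whether tert-butyl in place of phenyl changes the clearance at all on this core.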